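One More Methyl on the Amine of Compound 2

A few compounds are considered here, and "the series" means these few. Any claim that something is new, unique, unknown or untested is made for them only; others in the source may bear on it.

Compound 1 `C=C(c1cc(OC)nc(OC)c1)c1ccc(OC)c(O)c1`: 77 nM
Compound 2 `C=C(c1cc(Cl)nc(NC)c1)c1ccc(OC)c(O)c1`: 19 nM

In a functional assay on HepG2 cells (Homo sapiens) for antiproliferative activity, read by MTT assay, with a stated time of 72 h (on this read-out lower numbers stand for stronger inhibition and higher numbers for weaker inhibition), compound 2 has the lower number of the pair at 19 nM, and its gap to compound 1 at 77 nM lies beyond the usual scatter. Compound 3 `C=C(c1cc(Cl)nc(N(C)C)c1)c1ccc(OC)c(O)c1` alters compound 2 in one place: methyl in place of hydrogen on a nitrogen on an aromatic ring. This puts methyl in place of hydrogen on a nitrogen on an aromatic ring, turning methylamino into dimethylamino. Among the compounds with values here, no measured pair shows this change, so any expectation is loose. A small rise in the number, meaning slightly weaker inhibition, is expected, with the estimated step of a 1.8-fold higher number from compound 2 to compound 3 (0.27 log units; within the scatter). For compound 3, the expected value is 35 nM, with an estimated range of 10 nM to 120 nM.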

Compound 3, half-maximal inhibitory concentration: 27 nM
Compound 3: middle estimate off by 1.3-fold (0.11 log units), on the high side; the measured number falls inside the stated range.
By their numbers in this assay, from the lowest: compounds 2 and 3 (each within the scatter of the next); then compound 1.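

Within the data shown here, this is the first pair that isolates this nitrogen. In this assay, methyl in place of hydrogen gives a 1.4-fold higher number from compound 2 to compound 3 (0.15 log units; within the scatter), so this read-out does not separate methylamino from dimethylamino. At this position, then, the second methyl is tolerated, but no information is available to explain this result. The compounds shown leave open how the unsubstituted amine would compare. They also leave open whether a longer chain such as ethyl, or a morpholine ring in this place, would stay within the scatter of compound 2.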